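Sulfonyl series: from nitro to chloro

The source may report more compounds than this note shows. Statements on the series, on what has been measured and on what is new or still open speak of the compounds shown alone.

Measured in a functional assay on HepG2 cells (Homo sapiens) for antiproliferative activity, read by MTT assay, with a stated time of 24 h; on this read-out lower numbers stand for stronger inhibition and higher numbers for weaker inhibition:
- compound 1 `O=S(=O)(c1ccc(Cl)cc1)n1c(-c2cn(-c3ccccc3)nc2-c2ccc(F)cc2)nc2ccccc21` gives 4230 nM
- compound 2 `COc1ccc(S(=O)(=O)n2c(-c3cn(-c4ccccc4)nc3-c3ccc(C(F)(F)F)cc3)nc3ccccc32)cc1` gives 370 nM
- compound 3 `O=[N+]([O-])c1ccc(S(=O)(=O)n2c(-c3cn(-c4ccccc4)nc3-c3ccc(C(F)(F)F)cc3)nc3ccccc32)cc1` gives 1070 nM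

Compound 3, at 1070 nM, holds the middle place among the three numbers, above compound 2 and below compound 1. The next compound to be read is compound 4 `O=S(=O)(c1ccc(Cl)cc1)n1c(-c2cn(-c3ccccc3)nc2-c2ccc(C(F)(F)F)cc2)nc2ccccc21`, which has chloro in place of nitro on an aromatic carbon.

Among the measured compounds shown here, only one measured step bears directly on this site, a 2.9-fold higher number from compound 2 to compound 3 (0.46 log units; beyond the scatter), and it is modest. That step replaces methoxy with nitro and does not involve chloro, so it gives only a rough scale for changes at this position. Compound 4 shares the (4-chlorophenyl)sulfonyl group with compound 1, at 4230 nM, but differs from it elsewhere, so that number is a loose guide only. In this assay the expected change is a 1.2-fold lower number from compound 3 to compound 4 (0.08 log units; within the scatter), which is expected to stay within the usual scatter and to have no firm direction. Compound 4 is estimated at 900 nM, with an expected range from 300 nM to 2800 nM.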

Compound 4, half-maximal inhibitory concentration: 3930 nM
For compound 4 the middle estimate is 4.4-fold (0.64 log units) below the measured one; measured number outside the range, above it.
By their numbers in this assay, from the lowest: compound 2; then compound 3; then compounds 4 and 1 (each within the scatter of the next).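

In this assay, with the rest of the structure unchanged, chloro at this position gives a 3.7-fold higher number from compound 3 to compound 4 (0.57 log units; beyond the scatter) and an 11-fold higher number from compound 2 to compound 4 (1.03 log units; beyond the scatter); the position can therefore shift the number well beyond what the earlier methoxy-to-nitro comparison, a 2.9-fold higher number from compound 2 to compound 3 (0.46 log units; beyond the scatter), had shown. Among these three compounds, the numbers rise from methoxy in compound 2 through nitro in compound 3 to chloro in compound 4, so the single earlier step gave too small a scale for this site. The other changed site reads differently: with chloro held constant, trifluoromethyl in place of fluoro on an aromatic carbon gives a 1.1-fold lower number from compound 1 to compound 4 (0.03 log units; within the scatter), so that change shows no resolved effect in this pair.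

No supporting data at hand account for the order of the three groups at this position. Going by these compounds, it remains open where an amine, a carboxylic acid or a longer alkoxy chain would fall at this position, and whether trifluoromethyl and fluoro would also read alike with methoxy or nitro in place of chloro.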